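This account rests on a few compounds, and the source may have more. Where it says the series, first, only, none or still open, it means among the compounds named here.

Among the compounds with values here, compound 1, with the structure `Cn1c(-c2ccc(F)cc2)nc2c(NC3CCCC3)ncnc21`, is one of two compounds measured in an assay on CHO cells for displacement of a labelled ligand from adenosine receptor A1 (Homo sapiens), read by scintillation counting, with a stated time of 3 h; a higher number here means a weaker inhibitor, a lower number a stronger inhibitor. In this assay compound 1 gives 6.2 nM, while compound 2, with the structure `CCCn1c(-c2ccccc2)nc2c(NC3CCOC3)ncnc21`, gives 25 nM; of the two numbers, that of compound 1 is the lower one. The two compounds differ in more than one place, so their comparison carries no single structural reading.

Compound 3, with the structure `Cn1c(-c2ccc(O)cc2)nc2c(NC3CCCC3)ncnc21`, is not yet measured. Its structure differs from that of compound 1 in one place: hydroxy in place of fluoro on an aromatic carbon. Within the data shown here, no measured pair shows this exchange here, so its effect on this assay is unknown. A step of modest size is expected, in the direction of a somewhat higher number and possibly within the scatter, estimated as a 1.9-fold higher number from compound 1 to compound 3 (0.29 log units; within the scatter). Compound 3 is thus expected to give about 12 nM, within a range from 4 nM to 40 nM.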

Compound 3, inhibition constant: 17 nM
Beside the measured number, compound 3's estimate is 1.4-fold (0.15 log units) below it, and the stated range covers the measured number.
By their numbers in this assay, from the lowest: compound 1; then compounds 3 and 2 (each within the scatter of the next).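

Within the data shown here, compound 3 gives the first reading at this position that is confined to one place, and in this assay the change from 4-fluorophenyl to 4-hydroxyphenyl brings a 2.7-fold higher number from compound 1 to compound 3 (0.44 log units; beyond the scatter) on an otherwise unchanged structure. The position therefore responds to this exchange, though the step is modest, and compound 3 still gives 17 nM with a hydroxy group that adds a hydrogen-bond donor and acceptor where fluoro counts neither. Nothing in the data given bears on the reason for this step.

The compounds shown leave open how a methoxy group, a chloro group or an amine on this same aromatic carbon would read. They also leave open whether the exchange of fluoro for hydroxy brings a step of similar size when the other parts of the structure differ.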